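Replacing Methyl with Phenyl on the Amino Nitrogen

The source may report more compounds than this note shows. Statements on the series, on what has been measured and on what is new or still open speak of the compounds shown alone.

Measured compounds and their values:
compound 1, `CCOc1ccc(-n2nnc3n[nH]c(NC)c3c2=O)cc1`: 12400 nM
compound 2, `C=CCN/C(SC)=C(/C#N)C(=O)Nc1ccc(OCC)cc1`: 18500 nM
compound 3, `CCOc1ccc(NC(=O)c2c(N)n[nH]c2Nc2ccccc2)cc1`: 4470 nM

All three compounds were tested in a functional assay on CCRF-CEM cells (Homo sapiens) for cytotoxicity, read by resazurin assay, with a stated time of 48 h; on this read-out higher numbers stand for weaker inhibition and lower numbers for stronger inhibition. Among the three numbers, compound 1 has the second highest. Its nearest neighbour is compound 2, whose number is higher, but the gap between them lies within the usual scatter, so the two cannot be told apart. Compound 3 stands furthest away with a lower number, and this gap lies beyond the scatter. Compound 3 is built on a different core, so its value does not show what a single change on compound 1 would do.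

Compound 4, `CCOc1ccc(-n2nnc3n[nH]c(Nc4ccccc4)c3c2=O)cc1`, has not yet been measured. It differs from compound 1 in one place: phenyl in place of methyl on a nitrogen on an aromatic ring. Within the data shown here, no pair of measured compounds shows this exact change, so there is no measured step to lean on. A modest step toward lower numbers, or none beyond the scatter, is expected. Compound 4 is expected to give 7000 nM, with a range from 2500 nM to 20000 nM. This estimate means a step of a 1.8-fold lower number from compound 1 to compound 4 (0.25 log units; within the scatter), which is expected to fall within the scatter.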

Compound 4, half-maximal inhibitory concentration: 5920 nM
The estimate for compound 4 lay 1.2-fold (0.07 log units) above the measured number, and the stated range covers the measured number.
By their numbers in this assay, from the lowest: compounds 3 and 4 (each within the scatter of the next); then compounds 1 and 2 (each within the scatter of the next).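

In this assay, among these compounds, the move from methylamino to anilino gives a 2.1-fold lower number from compound 1 to compound 4 (0.32 log units; beyond the scatter) and so provides the first direct reading of this position, since the earlier compounds differ from one another in more than one place. The nitrogen on the aromatic ring can carry phenyl, with its six-membered aromatic ring of carbon only, in place of the single carbon of methyl, and the cytotoxicity does not weaken; the number moves modestly lower. The data show only the size and direction of this step, and nothing given here bears on what lies behind it.

A single pair cannot separate the effect of having an aromatic ring on this nitrogen from that of simply having more carbon atoms there, so benzyl, cyclohexyl or a plain ethyl chain at the same place would be needed to tell these apart. Also open, on these data alone, is whether a phenyl ring carrying a methoxy group or a chlorine atom would move the number further, or leave it within the usual scatter of compound 4.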